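A Smaller Fused Group on the Carbonyl Carbon

The compounds below may be only part of what the source reports. "The series", "measured", "known", "first", "only" and "open" are said of these compounds alone.

In an ADME assay on the whole organism (strain Sprague-Dawley) for pharmacokinetics, with Rattus norvegicus as the target, at a dose of 2 mg/kg by the oral route (on this read-out higher numbers stand for higher oral bioavailability and lower numbers for lower oral bioavailability), compound 1 `Nc1nc2c(s1)CCC[C@H]2C(=O)Nc1ccc(C[C@@H]2CC[C@H]([C@H](O)c3ccccc3)N2)cc1` gives 0%. Compound 2 `Nc1nc2c(s1)CC[C@H]2C(=O)Nc1ccc(C[C@@H]2CC[C@H]([C@H](O)c3cccnc3)N2)cc1` gives 0%, which leaves compound 1 level with compound 2, and the two cannot be separated on these numbers. Neither compound therefore offers any sign of measurable oral exposure in the rat.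

Compound 3 `O=C(Nc1ccc(C[C@@H]2CC[C@H]([C@H](O)c3ccccc3)N2)cc1)[C@@H]1CCc2scnc21` has not yet been measured. It is reached from compound 1 by a single exchange on a carbonyl carbon: a group of 8 heavy atoms (6 carbon, 1 nitrogen, 1 sulfur; one five-membered non-aromatic ring of carbon only, one five-membered aromatic ring with 2 hetero atoms) in place of a group of 10 heavy atoms (7 carbon, 2 nitrogen, 1 sulfur; one five-membered aromatic ring with 2 hetero atoms, one six-membered non-aromatic ring of carbon only), on a carbonyl carbon. The group that enters again holds a five-membered aromatic ring with 2 hetero atoms, but its non-aromatic ring of carbon only is five-membered rather than six-membered.

For the measured compounds named here, no measured pair of compounds isolates this exchange, so the data give no direct guide to the size of its effect. With compound 1 at 0%, the result in this assay can only hold or move upward. A small upward step is expected, and it may not clear the usual scatter. The estimated change is a number 10 percentage points higher from compound 1 to compound 3 (within the scatter). For compound 3 the expected value is 10%, within an estimated range of 0% to 30%.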

Compound 3, oral bioavailability: 12%
Beside the measured number, compound 3's estimate is 2 percentage points below it; low and high end bracket the measured number.
By their numbers in this assay, from the lowest: compounds 1 and 2 (each within the scatter of the next); then compound 3.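

In this assay, the exchange on the carbonyl carbon gives a number 12 percentage points higher from compound 1 to compound 3 (beyond the scatter), so the group held there can shift this read-out away from the floor of the two earlier compounds, something they could not show as they differ from each other in more than one place and sit level. The exchange is not a single-feature change: the entering group has a five-membered rather than a six-membered non-aromatic ring of carbon only, and it also carries 0 hydrogen-bond donors and 2 hydrogen-bond acceptors against 1 and 3 in the group that leaves, so the step belongs to the whole group and not to any one of these differences. No measurement available here explains the step.

The compounds shown leave open which of these differences carries the step, and a methyl group or an acetamide on the five-membered aromatic ring of the entering group would bear on that question. They also leave open whether the step would hold with the pyridine ring of compound 2 in place of the phenyl ring of compound 3.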